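Methoxy to Hydroxy on a Cytotoxicity Limit

The source may report more compounds than this note shows. Statements on the series, on what has been measured and on what is new or still open speak of the compounds shown alone.

Compound 1 `O=C(Nc1cccc(-n2cc(-c3ccncc3)c(-c3ccc(Cl)c(O)c3)n2)c1)Nc1cccc(C(F)(F)F)c1`: in a functional assay on A549 cells (Homo sapiens) for inhibition, read by sulforhodamine B assay, with a stated time of 48 h (a higher number here means that more compound is tolerated, a lower number that less compound is tolerated), compound 1 gives > 32500 nM, a limit.
Compound 2 `COc1cc(-c2nn(-c3cccc(NC(=O)c4cccc(C(F)(F)F)c4)c3)cc2-c2ccncc2)ccc1Cl`: compound 2 gives > 50000 nM, a limit.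
Compound 3 `COc1cc(-c2nn(-c3cccc(NC(=O)Nc4ccc(Cl)c(Cl)c4)c3)cc2-c2ccncc2)ccc1Cl`: compound 3 gives > 50000 nM, a limit.

Compound 3 stands at the limit of > 50000 nM in this assay, at which 2 of the 3 values shown sit. Compound 1 stands at the limit of > 32500 nM in this assay, at which 1 of the 3 values shown sits. No measured value is a number, so the step that the two limits leave unreadable from compound 2 to compound 3 cannot be sized. Compound 4 `O=C(Nc1cccc(-n2cc(-c3ccncc3)c(-c3ccc(Cl)c(O)c3)n2)c1)Nc1ccc(Cl)c(Cl)c1` differs from compound 3 by hydrogen in place of methyl on an oxygen on an aromatic ring. Compound 1 already carries the hydroxy group and is also tolerated only up to its limit; compound 2 and compound 3 share the methoxy group and are likewise at a limit. With three limits and no readable step, the expectation for compound 4 is that the limit is reached once more, an expected step of a number no higher from compound 3 to compound 4 (the limit leaves the size open), so the estimate for compound 4 is 50000 nM, ranging from 20000 nM to 100000 nM.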

Compound 4, concentration lethal to 50% of the cells: > 32500 nM
Compound 4 was reported as a limit (the forecaster's own chance of this, stated with the estimate: 85%); the middle value lies beyond the limit too.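

The result for compound 4 is a limit, as are those for compound 3 and compound 1, so neither step to compound 4 can be read. The compounds shown leave open whether methoxy to hydroxy changes toxicity to these cells at all.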